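The source may hold more compounds than are shown below. What is called first, only, known or untested is meant among the compounds shown, and "the series" means these compounds.

Three compounds have been measured in a functional assay on SK-MEL-28 cells (Homo sapiens) for cytotoxicity, read by MTT assay; on this read-out higher numbers stand for weaker inhibition and lower numbers for stronger inhibition:

Compound 1 `O=S(=O)(NCCCNc1nccc(-c2c(-c3cccc(F)c3)nc3sccn23)n1)c1ccc(Br)cc1` gives 9400 nM
Compound 2 `COc1ccc(S(=O)(=O)NCCCNc2nccc(-c3c(-c4cccc(F)c4)nc4sccn34)n2)cc1` gives 8980 nM
Compound 3 `O=S(=O)(NCCCNc1nccc(-c2c(-c3cccc(F)c3)nc3sccn23)n1)c1ccc(Cl)cc1` gives 8450 nM

Compound 2 stands second highest of the three numbers; its nearest neighbour is compound 1 and its furthest is compound 3, and both gaps lie within the scatter. Compound 4 `Cc1ccc(S(=O)(=O)NCCCNc2nccc(-c3c(-c4cccc(F)c4)nc4sccn34)n2)cc1` differs from compound 2 as follows: methyl in place of methoxy on an aromatic carbon. The measured steps that bear on this exchange of a group on an aromatic carbon are a 1.0-fold lower number from compound 1 to compound 2 (0.02 log units; within the scatter), a 1.1-fold lower number from compound 2 to compound 3 (0.03 log units; within the scatter) and a 1.1-fold lower number from compound 1 to compound 3 (0.05 log units; within the scatter); none of them moves beyond the scatter. For compound 4 the expected step is therefore a 1.0-fold higher number from compound 2 to compound 4 (0.00 log units; within the scatter), with no change beyond the scatter. Compound 4 is estimated at 9000 nM, within a range of 4500 nM to 18000 nM.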

Compound 4, half-maximal inhibitory concentration: 9500 nM
The estimate for compound 4 lay 1.1-fold (0.02 log units) below the measured number; the range from low to high includes it.
By their numbers in this assay, from the lowest: compounds 3, 2, 1 and 4 (each within the scatter of the next).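

In this assay, the exchange of 4-methoxyphenyl for 4-methylphenyl gives a 1.1-fold higher number from compound 2 to compound 4 (0.02 log units; within the scatter), and the exchanges from the other two groups give a 1.1-fold higher number from compound 3 to compound 4 (0.05 log units; within the scatter) and a 1.0-fold higher number from compound 1 to compound 4 (0.00 log units; within the scatter). Methyl, with one heavy atom and no hydrogen-bond acceptor, thus joins methoxy, chloro and bromo at this position, and all four compounds read alike. No measured evidence here accounts for this lack of change. From the compounds shown here alone, whether an amine or a carboxylic acid at this position would move the number beyond the scatter stays open.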